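From a Phenyl to a Benzyloxy-Bearing Chain at One Place

The source may hold more compounds than are shown below. What is called first, only, known or untested is meant among the compounds shown, and "the series" means these compounds.

Compound 2 `CC(C)C[C@@H]1CN[C@@H](Cc2ccccc2)C(=O)N[C@H](CCC(N)=O)C(=O)N[C@@H](Cc2c[nH]c3ccccc23)C(=O)N[C@H](Cc2ccccc2)C(=O)NCCC(=O)N1` stands lowest of the two numbers in a functional assay for antagonist activity at Substance-K receptor (Oryctolagus cuniculus) (on this read-out higher numbers stand for weaker binding and lower numbers for tighter binding), where compound 2 gives 79.4 nM. Within the data shown here, its nearest neighbour is compound 1 `CSCC[C@@H]1NC[C@@H](CC(C)C)NC(=O)CCNC(=O)[C@@H](Cc2ccccc2)NC(=O)[C@H](Cc2c[nH]c3ccccc23)NC(=O)[C@@H](CCC(N)=O)NC1=O`, which in this assay gives 224 nM; the only measured step, a 2.8-fold lower number from compound 1 to compound 2 (0.45 log units; beyond the scatter), came with phenyl in place of (methylsulfanyl)methyl on a saturated chain carbon bound to a saturated ring carbon. Compound 3 `CC(C)C[C@@H]1CN[C@@H](CCC(N)OCc2ccccc2)C(=O)N[C@H](CCC(N)=O)C(=O)N[C@@H](Cc2c[nH]c3ccccc23)C(=O)N[C@H](Cc2ccccc2)C(=O)NCCC(=O)N1` alters the same place: 2-amino-2-(benzyloxy)ethyl in place of phenyl on a saturated chain carbon bound to a saturated ring carbon. Among the measured compounds shown here, no measured step covers this change. The step of a 2.8-fold lower number from compound 1 to compound 2 (0.45 log units; beyond the scatter) shows only that moving to phenyl brought a modest gain, and that phenyl is now replaced rather than kept. Compound 3 is therefore expected to give back part of that gain, with an estimated step of a 2.0-fold higher number from compound 2 to compound 3 (0.30 log units; within the scatter) in this assay. The estimate for compound 3 is 160 nM, with a range from 40 nM to 650 nM.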

Compound 3, dissociation constant: 53.7 nM
Compound 3: middle estimate off by 3.0-fold (0.47 log units), on the high side; the range from low to high includes it.
By their numbers in this assay, from the lowest: compounds 3 and 2 (each within the scatter of the next); then compound 1.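

In this assay, the step of a 1.5-fold lower number from compound 2 to compound 3 (0.17 log units; within the scatter) lies within the scatter, so this position accepts 2-amino-2-(benzyloxy)ethyl in place of phenyl without a measurable change, although the entering group is larger and adds a nitrogen and an oxygen. Among these compounds, the step of a 4.2-fold lower number from compound 1 to compound 3 (0.62 log units; beyond the scatter) lies beyond the scatter, showing that phenyl bound directly at this place is not the only group that reads better than the one in compound 1. No evidence at hand accounts for this result.

The compounds shown leave open which part of 2-amino-2-(benzyloxy)ethyl matters at this position, the amine or the benzyloxy group. They also leave open how a carboxylic acid, a simple amine or a longer chain ending in phenyl would read here.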